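Trihydroxyphenyl in Place of Methylthiophenyl: a Growth-Inhibition Step

The source may hold more compounds than are shown below. What is called first, only, known or untested is meant among the compounds shown, and "the series" means these compounds.

Measured so far in a functional assay on DU-145 cells (Homo sapiens) for inhibition, read by trypan blue exclusion, with a stated time of 96 h; on this read-out higher numbers stand for weaker inhibition of growth and lower numbers for stronger inhibition of growth:
compound 1, `Cc1ccsc1/C=C(/SCc1ccc(F)cc1)C(=O)c1ccc(Br)cc1`, gives 50000 nM.
compound 3, `Cc1ccc(S/C(=C/c2sccc2C)C(=O)c2ccc(Br)cc2)cc1`, gives 50000 nM.
compound 2, `O=C(/C(=C\c1c(O)cc(O)cc1O)Sc1ccccc1Br)c1ccc(Br)cc1`, is reported only as a limit of this assay, > 100000 nM.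

Compound 3 stands level with compound 1; the step of no change at the digits printed from compound 1 to compound 3 (within the scatter) shows that the group on the sulfur did not move the read-out. Compound 4, `Cc1ccc(S/C(=C/c2c(O)cc(O)cc2O)C(=O)c2ccc(Br)cc2)cc1`, differs from compound 3 by 2,4,6-trihydroxyphenyl in place of 3-methylthiophen-2-yl on a double-bonded chain carbon bound to a double-bonded chain carbon. Within the data shown here, no measured step follows exactly this change. Compound 2 carries the same 2,4,6-trihydroxyphenyl and sits at the limit (the limit of > 100000 nM in this assay, at which 1 of the 3 values shown sits). Since the sulfur substituent proved indifferent from compound 1 to compound 3, compound 4 is expected to resemble compound 2 and to weaken, a step of a 2.0-fold higher number from compound 3 to compound 4 (0.30 log units; within the scatter). Compound 4 is estimated at 100000 nM, between 40000 nM and 300000 nM.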

Compound 4, concentration for 50% growth inhibition: > 100000 nM
Compound 4: no number, only a limit; the forecaster's own chance of this, stated with the estimate: 60%; the middle value sits exactly at the limit.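

In this assay, 2,4,6-trihydroxyphenyl in place of 3-methylthiophen-2-yl gives an at least 2.0-fold higher number from compound 3 to compound 4 (0.30 log units; that floor lies within the scatter). Compound 4 gives > 100000 nM, which is a limit of the assay and not a number. Compound 2 and compound 4 now both stand at this limit, and the step between them cannot be read: the limit of > 100000 nM in this assay, at which 2 of the 4 values shown sit.

Going by these compounds, how large the step to 2,4,6-trihydroxyphenyl truly is remains open. Also open, on these data alone, is how an amine or a carboxylic acid would read at this place on the double-bonded chain carbon.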